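A few compounds are considered here, and "the series" means these few. Any claim that something is new, unique, unknown or untested is made for them only; others in the source may bear on it.

Working notes on the series. In a functional assay on KYSE-450 cells (Homo sapiens) for inhibition, read by MTT assay, with a stated time of 48 h (a lower number here means a stronger inhibitor, a higher number a weaker inhibitor), compound 1 `COc1ccc(CN(C(C)=O)c2cc(OC)c(OC)c(OC)c2)cc1O` gives 160 nM, the lowest of the three numbers measured. Compound 2 `C/C=C/C(=O)N(Cc1ccc(OC)c(OC)c1)c1cc(OC)c(OC)c(OC)c1` gives 39100 nM in this assay and compound 3 `COc1cc(NCc2cccc(O)c2)cc(OC)c1OC` gives 71300 nM, both gaps to compound 1 lying beyond the scatter. Within the data shown here, no step between measured compounds that differ in a single place is available, so the next pair must be judged from the structural change alone. Compound 4 `CCC(=O)N(Cc1ccc(OC)c(O)c1)c1cc(OC)c(OC)c(OC)c1` differs from compound 1 as follows: methyl in place of hydrogen on a saturated chain carbon bound to a carbonyl carbon. A change this small is expected to leave the number close to that of compound 1, with no step beyond the scatter in either direction: a 1.3-fold higher number from compound 1 to compound 4 (0.10 log units; within the scatter). Compound 4 is therefore estimated at 200 nM in this assay, within 70 nM to 600 nM.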

Compound 4, half-maximal inhibitory concentration: 98 nM
The estimate for compound 4 lay 2.0-fold (0.31 log units) above the measured number; measured number inside the range.
By their numbers in this assay, from the lowest: compounds 4 and 1 (each within the scatter of the next); then compounds 2 and 3 (each within the scatter of the next).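

Among these compounds, the first single-place step, acetyl to propanoyl, reads a 1.6-fold lower number from compound 1 to compound 4 (0.21 log units; within the scatter) in this assay and so stays within the scatter. Among the compounds shown here, this saturated chain carbon bound to a carbonyl carbon therefore takes methyl in place of hydrogen without a measurable change in the number, which the earlier compounds could not show. No measured evidence bears on this result. As far as these compounds go, whether the number also holds with a longer chain such as butanoyl, or with a branched chain such as isobutyryl, remains open. From the compounds shown here alone, an amine or a carboxylic acid at this carbon is equally open.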